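This account rests on a few compounds, and the source may have more. Where it says the series, first, only, none or still open, it means among the compounds named here.

Measured compounds in a functional assay on PC-3 cells (Homo sapiens) for antiproliferative activity, read by MTT assay, with a stated time of 72 h; a higher number here means a weaker inhibitor, a lower number a stronger inhibitor:

- Compound 1, `COc1cc2ncnc(N3CCc4ccccc43)c2cc1NC(=O)C=C(C)C`: 7840 nM
- Compound 2, `CC(C)=CC(=O)Nc1cc2c(N3CCc4ccccc43)ncnc2cc1O[C@@H]1CCOC1`: 4620 nM
- Compound 3, `CC(C)=CC(=O)Nc1cc2c(N3CCCc4ccccc43)ncnc2cc1O[C@@H]1CCOC1`: 9020 nM

Compound 2 gives the lowest number of the three, but its lead is slight: the step of a 1.7-fold lower number from compound 1 to compound 2 (0.23 log units; within the scatter) and the step of a 2.0-fold higher number from compound 2 to compound 3 (0.29 log units; within the scatter) both lie within the scatter, so none of the three can be called the strongest or the weakest on this evidence.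

Compound 4, `CN(C)C/C=C/C(=O)Nc1cc2c(N3CCc4ccccc43)ncnc2cc1O[C@@H]1CCOC1`, has not yet been measured. It differs from compound 2 in one place: 3-(dimethylamino)prop-1-en-1-yl in place of 2-methylprop-1-en-1-yl on a carbonyl carbon. For the measured compounds named here, this exchange sits on the amide that hangs off the shared core, and it is a kind of change that none of the measured steps covers. The step from compound 1 to compound 2 alters the ether group, and the step from compound 2 to compound 3 alters the nitrogen-linked bicyclic group; both moved the number only within the scatter, and neither touches the chain on the carbonyl carbon. Going by the values given here, there is therefore no measured step that tells how large the change to compound 4 should be, or in which direction.

With nothing to anchor a shift, the expectation for compound 4 in this assay is a number close to that of compound 2, with a wide allowance either way; the expected step of a 1.3-fold lower number from compound 2 to compound 4 (0.12 log units; within the scatter) is small. The estimate for compound 4 is 3500 nM, between 900 nM and 12000 nM.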

Compound 4, half-maximal inhibitory concentration: 1230 nM
Beside the measured number, compound 4's estimate is 2.8-fold (0.45 log units) above it; low and high end bracket the measured number.
By their numbers in this assay, from the lowest: compound 4; then compounds 2, 1 and 3 (each within the scatter of the next).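

In this assay, for the compounds shown here, the exchange of 2-methylprop-1-en-1-yl for 3-(dimethylamino)prop-1-en-1-yl on the carbonyl carbon gives a 3.8-fold lower number from compound 2 to compound 4 (0.57 log units; beyond the scatter), so this chain is the first place where a single change moves the number beyond the scatter, though only modestly. The two earlier steps, one at the ether group and one at the nitrogen-linked bicyclic group, stayed within the scatter, which makes the amide chain the only one of the three changed places with a readable effect so far. Nothing available explains why the number falls with this exchange.

On these data alone, whether the nitrogen matters, or only the larger chain, stays open: a carbon chain of the same length without nitrogen could separate the two, and a pyrrolidine or morpholine in place of the dimethylamino group would show whether the kind of amine counts. As far as these compounds go, it is also open whether the same chain would lower the number to a similar extent on the structures of compound 1 and compound 3.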